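The source may report more compounds than this note shows. Statements on the series, on what has been measured and on what is new or still open speak of the compounds shown alone.

Measured compounds:
compound 1, `CCCCN(CC)c1cc(C)nc2c1NC(=O)CN2c1ccc(C(C)(C)C)cc1Br`: 4.2 nM
compound 2, `CCCCN(CC)c1cc(C)nc2c1NC(=O)CN2c1ccc(C)cc1Cl`: 4.4 nM
compound 3, `CCCN(CCC)c1cc(C)nc2c1NC(=O)CN2c1ccc(C(C)C)cc1Br`: 3.1 nM

These three values come from an assay on HEK-293T cells for displacement of a labelled ligand from corticotropin-releasing factor receptor 1 (Homo sapiens), read by scintillation counting, with a stated time of 2 h; on this read-out lower numbers stand for stronger inhibition and higher numbers for weaker inhibition. Compound 2 gives 4.4 nM in this assay, which is the highest of the three numbers, yet its separation from compound 1 at 4.2 nM and from compound 3 at 3.1 nM lies within the scatter, so the three compounds cannot be told apart on these data.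

Compound 4, `CCCCN(CC)c1cc(C)nc2c1NC(=O)CN2c1ccc(Br)cc1CC`, has not yet been measured in this assay. It keeps the shared core and the amine substituent of compound 2 and differs only in the aryl group on the ring nitrogen: 4-bromo-2-ethylphenyl in place of 2-chloro-4-methylphenyl on a nitrogen on an aromatic ring in a ring. Both the group that leaves and the group that enters carry one halogen and one alkyl group, but the halogen and alkyl of compound 4 are arranged differently from those of every measured compound, so the measured set offers no direct guide to this change.

Compound 4 is therefore expected to remain in the same region as compound 2, with a step of a 1.8-fold higher number from compound 2 to compound 4 (0.26 log units; within the scatter) that may sit at the edge of the scatter or somewhat beyond it toward a weaker result. The estimate for compound 4 in this assay is 8 nM, with a range from 2.5 nM to 30 nM.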

Compound 4, inhibition constant: 2.5 nM
Beside the measured number, compound 4's estimate is 3.2-fold (0.51 log units) above it; measured number inside the range.
By their numbers in this assay, from the lowest: compounds 4, 3, 1 and 2 (each within the scatter of the next).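

In this assay the exchange of 2-chloro-4-methylphenyl for 4-bromo-2-ethylphenyl on a nitrogen on an aromatic ring in a ring gives a 1.8-fold lower number from compound 2 to compound 4 (0.25 log units; within the scatter) and so leaves the two aryl groups indistinguishable on this read-out. Among the compounds shown here, this is the first step in the set that changes one place only, and it shows that this position tolerates a different halogen, a different alkyl group and a different arrangement of the two, with one more heavy atom, without any shift that stands clear of the scatter. No other kind of measurement is at hand that bears on this result.

The compounds shown leave open whether an aryl group with no halogen, or one carrying a methoxy or trifluoromethyl group, would be tolerated at this position in the same way. They also leave open whether a longer chain such as propyl could take the place of the ethyl group, and whether 4-bromo-2-ethylphenyl would give a similar number alongside the dipropylamino group of compound 3.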